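The compounds below may be only part of what the source reports. "The series", "measured", "known", "first", "only" and "open" are said of these compounds alone.

Measured compounds in a functional assay on HL-60 cells (Homo sapiens) for cytotoxicity, read by MTT assay, with a stated time of 24 h; on this read-out higher numbers stand for weaker inhibition and lower numbers for stronger inhibition:
- compound 1 `Nc1nn(Cc2cn(CCC(F)(F)C(F)(F)C(F)(F)C(F)(F)C(F)(F)C(F)(F)F)nn2)c2nc(-c3ccccc3)cc(C(F)(F)F)c12` gives 97.6 ug/mL
- compound 2 `Nc1nn(Cc2cn(CC(=O)Nc3ccccc3)nn2)c2nc(-c3ccccc3)cc(C(F)(F)F)c12` gives 96.3 ug/mL

Compound 2 has the lowest of the two numbers in this assay, but its nearest neighbour, compound 1, sits within the scatter of it, so the two values show no order; both stand for weak inhibition of the cells after the stated exposure. Among the compounds with values here, no pair of measured compounds that differ in one place is available, so no step size can be read off for this series.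

Compound 3 `Nc1nn(Cc2cn(CC(=O)Nc3c(F)cccc3F)nn2)c2nc(-c3ccccc3)cc(C(F)(F)F)c12` is the next compound to be measured. It differs from compound 2 by 2,6-difluorophenyl in place of phenyl on an amide-type nitrogen, the rest of the shared core unchanged. Within the data shown here, nothing among the measured compounds speaks for this exchange moving the number in either direction, and the two measured values already lie close together at the weak end of the read-out.

The expectation for compound 3 in this assay is therefore a value near that of compound 2, with the step of a 1.0-fold lower number from compound 2 to compound 3 (0.01 log units; within the scatter) estimated as none beyond the scatter. Compound 3 is estimated at 95 ug/mL, within a range from 55 ug/mL to 160 ug/mL.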

Compound 3, half-maximal inhibitory concentration: 32.8 ug/mL
For compound 3 the middle estimate is 2.9-fold (0.46 log units) above the measured one; measured number below the stated range.
By their numbers in this assay, from the lowest: compound 3; then compounds 2 and 1 (each within the scatter of the next).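

In this assay, within the data shown here, the group on the amide-type nitrogen is the first place where a single change can be read: 2,6-difluorophenyl in place of phenyl gives a 2.9-fold lower number from compound 2 to compound 3 (0.47 log units; beyond the scatter). The position therefore responds to substitution on this aromatic ring, although the two groups have the same ring and the same counts of hydrogen-bond donors and acceptors, carry no net charge, and differ only by the two fluorine atoms. No measurement at hand bears on why the number moves with this exchange.

This single pair leaves open whether both fluorine atoms are needed for the step, and whether a phenyl carrying one fluorine, a chlorophenyl or a methoxyphenyl on the same nitrogen would move the number in the same direction or by a similar amount. Also open, going by these compounds, is whether the step from phenyl to 2,6-difluorophenyl would recur with a different group on the rest of the shared core, and whether any such group would take the number further down from compound 3, measured at 32.8 ug/mL on this read-out.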